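Ether to amine in an aryl piperazine glycinamide series

A few compounds are considered here, and "the series" means these few. Any claim that something is new, unique, unknown or untested is made for them only; others in the source may bear on it.

The series shares a piperazine core in which one nitrogen carries an aryl ring and the other an acyl chain ending in a pyridylmethyl group. Compound 1, `O=C(COCc1ccccc1)N1CCN(c2ccncc2)CC1`, carries an unsubstituted pyridyl on the piperazine; in a functional assay on HEK293 cells for positive allosteric modulation of metabotropic glutamate receptor 5 (Homo sapiens), read by FLIPR and calcium flux (a lower number here means that less compound is needed, a higher number that more compound is needed for the effect), compound 1 reaches only the limit of > 25000 nM, with no number. Compound 2, `Cc1cc(Cl)ccc1N1CCN(C(=O)COCc2ccncc2)CC1`, gives 240 nM in this assay. Compound 3, `O=C(COCc1cccnc1)N1CCN(c2ccc(Cl)cc2Cl)CC1`, gives 1090 nM in this assay, the higher of the two numbers measured; the gap to compound 2 lies beyond the scatter.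

Compound 4, `O=C(CNCc1ccncc1)N1CCN(c2ccc(Cl)cc2Cl)CC1`, is not yet measured. It differs from compound 3 in one place: ((pyridin-4-yl)methyl)amino in place of (pyridin-3-yl)methoxy on a saturated chain carbon bound to a carbonyl carbon. Among the measured compounds shown here, no measured pair isolates this change, so the expectation rests on the neighbouring compounds alone. For the measured compounds named here, compound 2 shows that the pyridin-4-yl arrangement can sit with a good number, 240 nM, though on a different aryl ring; the oxygen-to-nitrogen swap has no precedent here. Compound 4 is therefore expected to stay close to compound 3, and the step from compound 3 to compound 4 is estimated as a 1.8-fold higher number from compound 3 to compound 4 (0.26 log units; within the scatter), without a firm direction. The estimate for compound 4 in this assay is 2000 nM, within 500 nM to 8000 nM.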

Compound 4, half-maximal effective concentration: 8500 nM
Compound 4: middle estimate off by 4.3-fold (0.63 log units), on the low side; the measured number lies above the stated range.
By their numbers in this assay, from the lowest: compound 2; then compound 3; then compound 4. At a limit, above all of these: compound 1.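

In this assay, ((pyridin-4-yl)methyl)amino in place of (pyridin-3-yl)methoxy on a saturated chain carbon bound to a carbonyl carbon gives a 7.8-fold higher number from compound 3 to compound 4 (0.89 log units; beyond the scatter), the only step shown between compounds that differ in one place. This position on the chain is therefore sensitive to what it carries: with the rest of compound 3 unchanged, the entering group, which has a hydrogen-bond donor where the leaving group has none, goes with a need for clearly more compound. Compound 4 still gives a measured number, and the one limit among the compounds shown belongs to compound 1: the limit of > 25000 nM in this assay, at which 1 of the 4 values shown sits.

The step changes the atom joined to the chain and the place of the ring nitrogen together, so it cannot say which of the two accounts for the shift, and a (pyridin-4-yl)methoxy or a ((pyridin-3-yl)methyl)amino group on the rest of compound 3 would separate them. From the compounds shown here alone, whether the amide-side amine hydrogen itself matters also stays open, and a tertiary amine carrying a methyl group at that nitrogen would bear on it.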